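Trimming the Chain on the Core Nitrogen

The compounds below may be only part of what the source reports. "The series", "measured", "known", "first", "only" and "open" are said of these compounds alone.

For the measured compounds named here, compound 1 `CC(C)n1nc(S(=O)(=O)c2cccc3ccccc23)c2cc(N3CCN(C)CC3)ccc21` is one of two compounds measured in a functional assay on HeLa cells for antagonist activity at 5-hydroxytryptamine receptor 6 (Homo sapiens); a higher number here means a larger maximal response, a lower number a smaller maximal response. In this assay compound 1 gives 98%. The other compound, compound 2 `Cn1nc(S(=O)(=O)c2ccccc2)c2cc(N3CCNCC3)ccc21`, gives 100% in this assay, a number within the scatter of the value of compound 1, so the two cannot be told apart. Compound 3 `CCn1nc(S(=O)(=O)c2cccc3ccccc23)c2cc(N3CCN(C)CC3)ccc21` differs from compound 1 in one place: hydrogen in place of methyl on a saturated chain carbon bound to an aromatic nitrogen and a saturated chain carbon. Going by the values given here, no measured pair shows this change, so its step size is unknown. Since both measured compounds reach nearly the full response, the expected step of a number 1 percentage points lower from compound 1 to compound 3 (within the scatter) is none beyond the scatter. Compound 3 is estimated at 97%, between 85% and 105%.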

Compound 3, largest response reached (reported as Imax), in percent of the reference or control that the assay uses: 100%
Estimate against measurement, compound 3: 3 percentage points below; low and high end bracket the measured number.
By their numbers in this assay, from the lowest: compounds 1, 2 and 3 (each within the scatter of the next).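

Cutting isopropyl to ethyl gives, in this assay, a number 2 percentage points higher from compound 1 to compound 3 (within the scatter), so the two compounds cannot be told apart. This is the first pair shown to isolate one change at this chain, and it shows that removing this single methyl leaves the maximal response indistinguishable. No separate measurement bears on this result. Still open, from the compounds shown here alone, is whether a longer chain, such as n-butyl, or a chain carrying an amine or a carboxylic acid, would keep the response at this level.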